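Oral tail flick activity of four related compounds

The source may hold more compounds than are shown below. What is called first, only, known or untested is meant among the compounds shown, and "the series" means these compounds.

Measured compounds:
Compound 1, `C[C@H](NC(=O)CN(c1ncnc2c1ncn2C1CCCCO1)C1CC1)C(=O)OCc1ccccc1`: in a functional assay on the whole organism (Tail, strain ICR) with Mus musculus as the target, in the tail flick test, with a stated time of 60 min, at a dose of 25 umol/kg by the oral route (on this read-out lower numbers stand for a weaker effect and higher numbers for a stronger effect at the one dose given), compound 1 gives 53%.
Compound 2, `O=C(OCc1ccccc1)[C@@H]1CCCN1C(=O)CN(c1ncnc2c1ncn2C1CCCCO1)C1CC1`: in this assay compound 2 gives 36.7%.
Compound 3, `CC[C@H](C)[C@H](NC(=O)CN(c1nc(Cl)nc2[nH]cnc12)C1CC1)C(=O)O`: in this assay compound 3 gives 36%.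

Compound 1 stands highest of the three numbers in this assay. Compound 2 sits nearest to it, lower by an amount beyond the scatter, and compound 3 sits furthest, also lower by an amount beyond the scatter. The three measured compounds differ from one another in several places at once, so no single structural change is isolated among them.

Compound 4, `C[C@@H](O)[C@H](NC(=O)CN(c1ncnc2c1ncn2C1CCCCO1)C1CC1)C(=O)OCc1ccccc1`, has not yet been measured. It differs from compound 1 by 1-hydroxyethyl in place of methyl on a saturated chain carbon bound to an amide-type nitrogen and a carbonyl carbon. Among the measured compounds shown here, no measured pair shows what this change alone does in this assay. A modest step is expected in this assay, more likely downward than upward, and it may well fall within the scatter. For compound 4 the expected value in this assay is 45%, with a range from 25% to 65%. The estimated step from compound 1 to compound 4 is a number 8 percentage points lower from compound 1 to compound 4 (within the scatter), anchored on compound 1 because it gives 53% as the starting point.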

Compound 4, a percentage reported as activity, at one dose (the size of the read-out at that dose, not a potency): 28.4%
Compound 4: the middle estimate sits 16.6 percentage points above what was measured, and the stated range covers the measured number.
By their numbers in this assay, from the lowest: compounds 4, 3 and 2 (each within the scatter of the next); then compound 1.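

In this assay, 1-hydroxyethyl in place of methyl on the saturated chain carbon bound to an amide-type nitrogen and a carbonyl carbon gives a number 24.6 percentage points lower from compound 1 to compound 4 (beyond the scatter). Among the compounds shown here, this is the first comparison that isolates a single change, and it shows that the read-out at this dose responds to the group at this position when the rest of compound 1 stays the same. Nothing measured here bears on why the read-out falls with this change.

The compounds shown do not separate the added carbon from the added hydroxyl, so an ethyl or hydroxymethyl group in the same place would be needed to tell which part of 1-hydroxyethyl goes with the lower number. Also open, on these data alone, are the other configuration of the 1-hydroxyethyl stereocentre and whether a longer chain or an amine at this position would behave like methyl or like 1-hydroxyethyl.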